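The source may hold more compounds than are shown below. What is called first, only, known or untested is meant among the compounds shown, and "the series" means these compounds.

Of the compounds shown here, three have been tested so far in a functional assay on HCT-116 cells (Homo sapiens) for cytotoxicity, read by sulforhodamine B assay, with a stated time of 48 h; on this read-out lower numbers stand for stronger inhibition and higher numbers for weaker inhibition. Compound 1 `CCCCNC(=O)N1Cc2c(NC(=O)c3ccc(F)cc3)nn(C(=O)C3CC3)c2C1` gives 23300 nM, and compound 2 `CC(=O)n1nc(NC(=O)c2ccccc2)c2c1CN(C(=O)c1cccc([N+](=O)[O-])c1)C2` gives 17300 nM. These two numbers lie within the usual scatter of each other, so compound 2 stands level with compound 1. Compound 3 `CC(=O)n1nc(NC(=O)c2ccccc2)c2c1CN(C(=O)c1ccc(-c3ccccc3)cc1)C2` gives > 90000 nM, which is a limit of the assay and not a number.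

Compound 4 `CC(=O)n1nc(NC(=O)c2ccccc2)c2c1CN(C(=O)c1cccc(Cl)c1)C2` shares its core with compound 2 and differs from it in one place: chloro in place of nitro on an aromatic carbon. The change turns 3-nitrophenyl into 3-chlorophenyl. Among the measured compounds shown here, no measured pair of compounds here shows what a single change of this kind does, so the expectation rests on compound 2 and its 17300 nM. As far as these compounds go, no step beyond the scatter is expected in this assay, and the direction remains open. The estimated change, a 1.2-fold higher number from compound 2 to compound 4 (0.06 log units; within the scatter), is expected to be small. For compound 4 the expected value is 20000 nM, with an estimated range from 8000 nM to 60000 nM.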

Compound 4, half-maximal inhibitory concentration: 17400 nM
Beside the measured number, compound 4's estimate is 1.1-fold (0.06 log units) above it, and the stated range covers the measured number.
By their numbers in this assay, from the lowest: compounds 2, 4 and 1 (each within the scatter of the next). At a limit, above all of these: compound 3.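

In this assay the move from 3-nitrophenyl to 3-chlorophenyl gives a 1.0-fold higher number from compound 2 to compound 4 (0.00 log units; within the scatter) and so compounds 2 and 4 stand level. Among the compounds shown here, at this place on the ring, meta to a large group, nitro with its 3 heavy atoms and 2 hydrogen-bond acceptors can give way to chloro, with 1 heavy atom and no hydrogen-bond acceptors, without a step beyond the scatter, which no earlier pair of compounds could show. The data shown give no cause for this level result.

Only nitro and chloro have been read at this place, so an amine, a carboxylic acid or a methoxy group there remains an open question. As far as these compounds go, whether any group at this place can move the number beyond the scatter also stays open.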